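This account rests on a few compounds, and the source may have more. Where it says the series, first, only, none or still open, it means among the compounds named here.

Working notes on the series in a functional assay on K562 cells (Homo sapiens) for antiproliferative activity, read by MTT assay, with a stated time of 5 days; on this read-out lower numbers stand for stronger inhibition and higher numbers for weaker inhibition.

Compound 1 `COc1ccc(C(=Cc2ccc(OC)c([N+](=O)[O-])c2)C(=O)c2cc(OC)c(OC)c(OC)c2)cc1` gives 2660000 nM. Compound 2 `COc1ccc(C=C(C(=O)c2cc(OC)c(OC)c(OC)c2)c2ccccc2)cc1[N+](=O)[O-]` returns only a limit of the assay, > 10000000 nM. Compound 3 `COc1cc(C(=O)C(=Cc2ccccc2)c2ccccc2)cc(OC)c1OC` gives 6300000 nM. Compound 4 `COc1ccc(C(=Cc2ccccc2)C(=O)c2cc(OC)c(OC)c(OC)c2)cc1` remains to be measured.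

The change from compound 2 to compound 1 is methoxy in place of hydrogen on an aromatic carbon; it made an at least 3.7-fold lower number from compound 2 to compound 1 (0.57 log units; beyond the scatter), the floor set by the limit of > 10000000 nM in this assay, at which 1 of the 3 values shown sits. The two cores differ by phenyl in place of 4-methoxy-3-nitrophenyl on a double-bonded chain carbon bound to a double-bonded chain carbon, with an at least 1.5-fold lower number from compound 2 to compound 3 (0.20 log units; that floor lies within the scatter). The change from compound 3 to compound 4 is methoxy in place of hydrogen on an aromatic carbon, the same change as before, made on the core of compound 3.

For compound 4 the step is expected to be a 2.5-fold lower number from compound 3 to compound 4 (0.40 log units; beyond the scatter), resting on the earlier step and on compound 3 at 6300000 nM. Compound 4 is estimated at 2500000 nM, within 1000000 nM to 6300000 nM.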

Compound 4, half-maximal inhibitory concentration: 4920000 nM
Compound 4: the middle estimate sits 2.0-fold (0.29 log units) below what was measured, and the stated range covers the measured number.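

In this assay the methoxy change does not carry over at its earlier size from one core to the other, giving a 1.3-fold lower number from compound 3 to compound 4 (0.11 log units; within the scatter): the same change on two cores in this assay, an at least 3.7-fold lower number (0.57 log units; beyond the scatter) from compound 2 to compound 1 and a 1.3-fold lower number (0.11 log units; within the scatter) from compound 3 to compound 4, at least 2.9-fold (0.46 log units) apart, beyond the scatter of two such steps

The swap of 4-methoxy-3-nitrophenyl for phenyl also depends on the core, giving a 1.8-fold higher number from compound 1 to compound 4 (0.27 log units; within the scatter): the same change on two cores in this assay, an at least 1.5-fold lower number (0.20 log units; that floor lies within the scatter) from compound 2 to compound 3 and a 1.8-fold higher number (0.27 log units; within the scatter) from compound 1 to compound 4, at least 2.9-fold (0.46 log units) apart, beyond the scatter of two such steps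

This does not show how large either gap really is or why the steps differ, and the earlier steps rest on compound 2, whose value is only a limit: the limit of > 10000000 nM in this assay, at which 1 of the 4 values shown sits.

Open, from the compounds shown here alone, is whether the size of the methoxy step depends on the nitro group, which compound 1 and compound 2 carry and compound 3 and compound 4 lack. Also open, going by these compounds, is how an amine in place of that nitro group would behave.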